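Notes on compound 4 in the aminopurinone series

This account rests on a few compounds, and the source may have more. Where it says the series, first, only, none or still open, it means among the compounds named here.

Measured so far in a functional assay (spleen, spleen) for activation, with Mus musculus as the target; on this read-out higher numbers stand for an effect only at larger amounts of compound and lower numbers for an effect already at smaller amounts:
- compound 1, `CCCCCNc1nc(N)c2nc(O)n(Cc3ccccc3)c2n1`, gives 0.1 uM
- compound 2, `CCCCCOc1nc(N)c2nc(O)n(Cc3ccccc3)c2n1`, gives 0.01 uM
- compound 3, `Nc1nc(SCc2ccccc2)nc2c1nc(O)n2Cc1ccccc1`, gives 0.1 uM

Compound 3 stands level with compound 1 and together they hold the highest numbers of the three; compound 2 sits apart, with a 10-fold higher number from compound 2 to compound 3 (1.00 log units; beyond the scatter). The move to compound 4, `CCSc1nc(N)c2nc(O)n(Cc3ccccc3)c2n1`, is methyl in place of phenyl on a saturated chain carbon bound to a sulfur. Among the measured compounds shown here, no measured step covers this kind of change: no change at the digits printed from compound 1 to compound 3 (within the scatter) and a 10-fold higher number from compound 2 to compound 3 (1.00 log units; beyond the scatter) swap the whole group on the aromatic carbon, not just its tail, so they bear on the step only indirectly. With no guide in this assay, a small shift toward a higher number is expected for compound 4, a 3.0-fold higher number from compound 3 to compound 4 (0.48 log units; beyond the scatter). Compound 4 is therefore estimated at 0.3 uM, within 0.05 uM to 2 uM.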

Compound 4, minimum effective concentration: 0.1 uM
The estimate for compound 4 lay 3.0-fold (0.48 log units) above the measured number; the measured number falls inside the stated range.
By their numbers in this assay, from the lowest: compound 2; then compounds 1, 3 and 4 (each within the scatter of the next).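

In this assay, methyl in place of phenyl on a saturated chain carbon bound to a sulfur shows that removing the ring from this tail leaves the read-out unmoved (no change at the digits printed from compound 3 to compound 4 (within the scatter)). Ethylsulfanyl also reads alike with pentylamino (no change at the digits printed from compound 1 to compound 4 (within the scatter)), whereas pentyloxy remains apart (a 10-fold higher number from compound 2 to compound 4 (1.00 log units; beyond the scatter)). No available data explain these results.

Still open, from the compounds shown here alone, is whether pentylsulfanyl, which would carry the same chain as pentyloxy and pentylamino, would read with the sulfur compounds or with compound 2. A carboxylic acid or an amine at the end of the ethyl tail also remains untested in the compounds shown.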